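Two Diketopiperazines and an Amide Homologue

A few compounds are considered here, and "the series" means these few. Any claim that something is new, unique, unknown or untested is made for them only; others in the source may bear on it.

The series rests on a shared diketopiperazine core carrying an isobutyl side chain. Compound 1 `CC(C)C[C@@H]1NC(=O)[C@H](CC(N)=O)NC1=O` was examined in a functional assay, tested at 2.5 mM (on this read-out lower numbers stand for less inhibition and higher numbers for more inhibition at the one concentration tested (going by the name of the read-out)), where compound 1 gives 0%. Compound 2 `CC(C)C[C@@H]1NC(=O)[C@H](CC(=O)O)NC1=O` carries a hydroxy in place of amino on a carbonyl carbon, and in this assay compound 2 gives 0%. The step of no change at the digits printed from compound 1 to compound 2 (within the scatter) shows that this exchange made no difference at the digits reported. Compound 2 therefore stands level with compound 1, both at the floor of the read-out.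

Compound 3 `CC(C)C[C@@H]1NC(=O)[C@H](CCC(N)=O)NC1=O` is the next member. Its difference from compound 2 is:

carbamoylmethyl in place of carboxy on a saturated chain carbon bound to a saturated ring carbon

Within the data shown here, only one measured step bears on this change, and it was flat: no change at the digits printed from compound 1 to compound 2 (within the scatter). The change from compound 2 to compound 3 touches the same side chain, and with two compounds already at the floor there is no measured movement to build on. The expected step is therefore no change at the digits printed from compound 2 to compound 3 (within the scatter), that is, none beyond the scatter. Compound 3 is estimated to give 0%, with a range from 0% to 10%.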

Compound 3, a percentage reported as inhibition, at one concentration (the size of the read-out at that concentration, not a potency): 0%
Beside the measured number, compound 3's estimate shows no gap at the digits printed; measured number inside the range.
By their numbers in this assay, from the lowest: compounds 1, 2 and 3 (each within the scatter of the next).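

Among these compounds, at this position, on a saturated chain carbon bound to a saturated ring carbon, the earlier compounds had tested only an exchange of hydroxy for amino on a carbonyl carbon. Compound 3 adds a change in the group itself: putting carbamoylmethyl in place of carbamoyl gives no change at the digits printed from compound 1 to compound 3 (within the scatter) in this assay, and putting carbamoylmethyl in place of carboxy gives no change at the digits printed from compound 2 to compound 3 (within the scatter). Among the compounds shown here, all three side chains therefore read the same at the one concentration tested, but with every value at zero, these steps can show no loss of inhibition, only that none of these changes raised it. Nothing here offers an explanation for this flat result.

Going by these compounds, whether an amine or a 2-carboxyethyl group at this position would lift the read-out above zero remains open. So does whether replacing the isobutyl side chain with a benzyl group, while keeping any of these three side chains, would give any inhibition at all.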